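The source may hold more compounds than are shown below. What is called first, only, known or untested is meant among the compounds shown, and "the series" means these compounds.

Compound 1 `COc1cc2cc(Oc3ccc(NC(=O)Nc4cccc(C(F)(F)F)c4)cc3)c(C)nc2cc1OC` and compound 2 `COc1cc2cc(Oc3ccc(NC(=O)Nc4ccc(Cl)c(C(F)(F)F)c4)cc3)c(C)nc2cc1OC` share one core and differ only in the aryl urea end. In a functional assay on Malme-3M cells (Homo sapiens) for inhibition, read by sulforhodamine B assay, with a stated time of 48 h (on this read-out lower numbers stand for higher toxicity in this test and higher numbers for lower toxicity in this test), compound 1 gives 33800 nM. As far as these compounds go, compound 2 reaches only a limit of the test in this assay, > 32500 nM, so the number itself stays unknown. The step that the limit leaves unreadable from compound 1 to compound 2 therefore cannot be sized, because the limit of > 32500 nM in this assay, at which 1 of the 2 values shown sits, sets the ceiling of what the test reports.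

Compound 3 `COc1cc2cc(Oc3ccc(NC(=O)Nc4ccc(Cl)c(Cl)c4)cc3)c(C)nc2cc1OC` comes next. It differs from compound 2 by chloro in place of trifluoromethyl on an aromatic carbon. Among the compounds with values here, no measured step covers this exchange; the only measured step, the one from compound 1 to compound 2, is itself unreadable. The account therefore expects compound 3 to stay where the two known compounds sit, near the top of the measurable window, with the step that the limit leaves unreadable from compound 2 to compound 3 expected to lie within the scatter. The expected value for compound 3 is 33000 nM, with a range from 15000 nM to 80000 nM.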

Compound 3, concentration lethal to 50% of the cells: 26700 nM
For compound 3 the middle estimate is 1.2-fold (0.09 log units) above the measured one; low and high end bracket the measured number.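

Chloro in place of trifluoromethyl, on the aromatic carbon ortho to a chloro group, gives an at least 1.2-fold lower number from compound 2 to compound 3 (0.08 log units; that floor lies within the scatter) in this assay and so brings this aryl urea end back to a readable number. Only a floor can be given for that step, because the value for compound 2 is a limit: the limit of > 32500 nM in this assay, at which 1 of the 3 values shown sits. Within the data shown here, the first fully readable comparison of the aryl urea ends is a 1.3-fold lower number from compound 1 to compound 3 (0.10 log units; within the scatter), so 3,4-dichlorophenyl and 3-(trifluoromethyl)phenyl cannot be told apart here.

The compounds shown leave open whether an amine or a carboxylic acid on this aromatic carbon would move the number away from where compound 1 and compound 3 stand. They also leave open how much the shared core, the same throughout, contributes to the result in this assay on these cells.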